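The compounds below may be only part of what the source reports. "The series", "measured", "known", "first", "only" and "open" are said of these compounds alone.

Measured so far in a functional assay for antagonist activity at transient receptor potential cation channel subfamily V member 1 (Rattus norvegicus), read by FLIPR; on this read-out lower numbers stand for lower potency and higher numbers for higher potency (the scale is a negative logarithm):
compound 1 `Cc1ccc(N2CC[C@@H](NC(=O)Nc3ccccc3Br)C2)cc1F`: 8.3
compound 2 `O=C(Nc1ccccc1Br)N[C@@H]1CCN(c2cccc(F)c2)C1`: 7.8

Compound 2 holds the lower of the two numbers in this assay; the step of a number 0.50 log units lower from compound 1 to compound 2 (beyond the scatter) separates it from compound 1, which gives the higher number. Compound 3 `O=C(Nc1ccccc1Br)N[C@@H]1CCN(c2ccc(Cl)cn2)C1` has not yet been measured. It differs from compound 2 in one place: 5-chloropyridin-2-yl in place of 3-fluorophenyl on an amine nitrogen in a ring. Going by the values given here, no measured step bears on this exchange of the ring on the amine nitrogen; the only step seen, a number 0.50 log units lower from compound 1 to compound 2 (beyond the scatter), concerns hydrogen in place of methyl on an aromatic carbon and gives no guide to swapping 3-fluorophenyl for 5-chloropyridin-2-yl. With nothing comparable to draw on, compound 3 is expected to land close to its parent, with an estimated step of a number 0.10 log units higher from compound 2 to compound 3 (within the scatter), inside the usual scatter. For compound 3 the estimated value in this assay is 7.9, with a range from 7.2 to 8.6.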

Compound 3, negative logarithm of the antagonist equilibrium constant: 7.3
Compound 3: the middle estimate sits 0.60 log units above what was measured; low and high end bracket the measured number.
By their numbers in this assay, from the lowest: compound 3; then compound 2; then compound 1.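

In this assay, the group on the amine nitrogen in the ring is not a neutral position: 5-chloropyridin-2-yl in place of 3-fluorophenyl gives a number 0.50 log units lower from compound 2 to compound 3 (beyond the scatter). In place of the 3-fluoro-4-methylphenyl group, the same entering group gives a number 1.00 log units lower from compound 1 to compound 3 (beyond the scatter), the widest gap among the three compounds, so the choice of this ring spans more of the range than the methyl change alone. No supporting data on hand account for this drop.

Going by these compounds, the exchange introduces the ring nitrogen and swaps fluorine for chlorine at once, so the share of each in the step stays open. A chlorophenyl ring on the same amine nitrogen would separate the halogen from the ring nitrogen, and a methyl group on the pyridine ring would test whether the gain seen with methyl on the phenyl ring carries over.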